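Amide aryl variation on a shared core: compound 3 to 4

The source may hold more compounds than are shown below. What is called first, only, known or untested is meant among the compounds shown, and "the series" means these compounds.

Measured compounds, all in an assay on isolated protein with metabotropic glutamate receptor 5 (Rattus norvegicus) as the target; on this read-out lower numbers stand for an effect already at smaller amounts and higher numbers for an effect only at larger amounts of compound:
compound 1 `O=C(Nc1cc(-c2ccccc2)nn1-c1ccccc1)c1ccc(F)c(F)c1`: compound 1 gives 20 nM
compound 2 `Cc1ccc(C(=O)Nc2cc(-c3ccccc3)nn2-c2ccccc2)cc1`: compound 2 gives 40 nM
compound 3 `O=C(Nc1cc(-c2ccccc2)nn1-c1ccccc1)c1cccc(F)c1`: compound 3 gives 65 nM

Compound 3 carries the highest number of the three. Its distance to compound 2 is small, a 1.6-fold higher number from compound 2 to compound 3 (0.21 log units; within the scatter), which lies within the scatter; its distance to compound 1 is larger, a 3.3-fold higher number from compound 1 to compound 3 (0.51 log units; beyond the scatter), which lies beyond it.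

Compound 4 `O=C(Nc1cc(-c2ccccc2)nn1-c1ccccc1)c1ccc(Cl)cc1` differs from compound 3 in one place: 4-chlorophenyl in place of 3-fluorophenyl on a carbonyl carbon. Going by the values given here, the steps that bear on this change are the other exchanges of the aryl group on the carbonyl carbon: a 2.0-fold higher number from compound 1 to compound 2 (0.30 log units; within the scatter) and a 1.6-fold higher number from compound 2 to compound 3 (0.21 log units; within the scatter), both within the scatter, and a 3.3-fold higher number from compound 1 to compound 3 (0.51 log units; beyond the scatter), modest and beyond it. The closest comparison is compound 2, whose aryl group also carries its single substituent in the 4-position and which gives 40 nM.

A small step downward is therefore expected, a 1.9-fold lower number from compound 3 to compound 4 (0.27 log units; within the scatter), likely within the scatter. The estimate for compound 4 in this assay is 35 nM, with a range from 12 nM to 100 nM.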

Compound 4, half-maximal effective concentration: 100 nM
Beside the measured number, compound 4's estimate is 2.9-fold (0.46 log units) below it; low and high end bracket the measured number.
By their numbers in this assay, from the lowest: compounds 1, 2, 3 and 4 (each within the scatter of the next, the first and the last beyond it).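

In this assay the exchange of methyl for chloro on the aromatic carbon, with the rest of the molecule unchanged, is modest but beyond the scatter (a 2.5-fold higher number from compound 2 to compound 4 (0.40 log units; beyond the scatter)), so the single substituent on this aryl group can move the number on its own. The exchange of 3-fluorophenyl for 4-chlorophenyl on the carbonyl carbon stays within the scatter (a 1.5-fold higher number from compound 3 to compound 4 (0.19 log units; within the scatter)), and these two aryl groups are not told apart here. Going by these compounds alone, the widest step at this place so far separates 3,4-difluorophenyl from 4-chlorophenyl, still modest (a 5.0-fold higher number from compound 1 to compound 4 (0.70 log units; beyond the scatter)).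

Nothing shown accounts for these steps. Open, from the compounds shown here alone, is how a methoxy group, a nitrile or an amine on this aryl group would compare with chloro and methyl.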